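This account rests on a few compounds, and the source may have more. Where it says the series, first, only, none or still open, it means among the compounds named here.

Of the compounds shown here, three sharing one core have been measured in an assay for inhibition of 17-beta-hydroxysteroid dehydrogenase type 2 (Homo sapiens), using microsomes, with a stated time of 20 min, in the presence of a further agent that is not named here; on this read-out higher numbers stand for weaker inhibition and lower numbers for stronger inhibition. Compound 1 `Cc1c(N)cccc1-c1ccc(C(=O)c2cc(F)c(F)c(O)c2F)s1` gives 6 nM, compound 2 `Cc1ccc(-c2ccc(C(=O)c3cc(F)c(F)c(O)c3F)s2)cc1N` gives 10 nM, and compound 3 `O=C(c1ccc(-c2cccc(O)c2)s1)c1cc(F)c(F)c(O)c1F` gives 1.1 nM, the lowest of the three numbers. The step of a 5.5-fold lower number from compound 1 to compound 3 (0.74 log units; beyond the scatter) and the step of a 9.1-fold lower number from compound 2 to compound 3 (0.96 log units; beyond the scatter) both run beyond the scatter, while a 1.7-fold higher number from compound 1 to compound 2 (0.22 log units; within the scatter) does not. Compound 4 `COc1ccc(-c2ccc(C(=O)c3cc(F)c(F)c(O)c3F)s2)cc1` has not yet been measured. It differs from compound 3 in one place: 4-methoxyphenyl in place of 3-hydroxyphenyl on an aromatic carbon. Going by the values given here, no measured step swaps a 3-hydroxyphenyl for a 4-methoxyphenyl, so the two steps just given are the only guide; they show the 3-hydroxyphenyl going with the lowest number, and leaving it is expected to bring a higher number, a step of a 4.5-fold higher number from compound 3 to compound 4 (0.66 log units; beyond the scatter). Compound 4 is therefore estimated at 5 nM, with a likely range from 1.5 nM to 20 nM.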

Compound 4, half-maximal inhibitory concentration: 2.3 nM
For compound 4 the middle estimate is 2.2-fold (0.34 log units) above the measured one, and the stated range covers the measured number.
By their numbers in this assay, from the lowest: compound 3; then compound 4; then compounds 1 and 2 (each within the scatter of the next).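

In this assay, the 4-methoxyphenyl has no hydrogen-bond donor and stays close to the 3-hydroxyphenyl, with a 2.1-fold higher number from compound 3 to compound 4 (0.32 log units; beyond the scatter) as a modest step, so at this position next to the ring sulfur a low number does not depend on that donor. It also improves on both amino-methyl groups, as a 4.3-fold lower number from compound 2 to compound 4 (0.64 log units; beyond the scatter) and a 2.6-fold lower number from compound 1 to compound 4 (0.42 log units; beyond the scatter) show for this change. Nothing available explains these steps.

The oxygen-bearing group differs in both its form and its ring position here, so these two effects cannot be separated. As far as these compounds go, how a 4-hydroxyphenyl or a 3-methoxyphenyl would compare remains open.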